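A few compounds are considered here, and "the series" means these few. Any claim that something is new, unique, unknown or untested is made for them only; others in the source may bear on it.

Compound 3 `Cc1cc(OCc2c(-c3[nH]c(=O)ccc3Cl)noc2C(C)C)ccc1-c1ccc2c(C(=O)O)cn(C)c2c1` gives 4130 nM in an assay on isolated protein for displacement of a labelled ligand from Bile acid receptor (Homo sapiens), read by scintillation proximity assay and radioligand binding (on this read-out higher numbers stand for weaker inhibition and lower numbers for stronger inhibition), the highest number of the three measured, with compound 2 `COc1ccc(Cl)c(-c2noc(C(C)C)c2COc2ccc(-c3ccc4c(C(=O)O)cn(C)c4c3)c(C)c2)n1` at 310 nM and compound 1 `Cc1cc(OCc2c(-c3c(Cl)ccc(=O)n3C)noc2C(C)C)ccc1-c1ccc2c(C(=O)O)cn(C)c2c1` at 235 nM. Compound 4 `Cc1cc(OCc2c(-c3ccn(C)c(=O)c3Cl)noc2C(C)C)ccc1-c1ccc2c(C(=O)O)cn(C)c2c1` differs from compound 3 by a group of 9 heavy atoms (6 carbon, 1 nitrogen, 1 oxygen, 1 chlorine; one six-membered aromatic ring with 1 hetero atom) in place of a group of 8 heavy atoms (5 carbon, 1 nitrogen, 1 oxygen, 1 chlorine; one six-membered aromatic ring with 1 hetero atom), on an aromatic carbon; the group that leaves carries a hydrogen-bond donor, the group that enters carries none. The measured steps that bear on this are an 18-fold higher number from compound 1 to compound 3 (1.24 log units; beyond the scatter) and a 13-fold higher number from compound 2 to compound 3 (1.12 log units; beyond the scatter), both large and both running from a pyridone without a donor to the one with it. Going back the other way, compound 4 is therefore expected to show a markedly lower number in this assay than compound 3, a step of a 9.2-fold lower number from compound 3 to compound 4 (0.96 log units; beyond the scatter), though the entering ring is attached differently from that in compound 1, so a full return is uncertain. Compound 4 is estimated at 450 nM, within a range of 150 nM to 1500 nM.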

Compound 4, half-maximal inhibitory concentration: 1720 nM
Compound 4: the middle estimate sits 3.8-fold (0.58 log units) below what was measured, outside the stated range (above it).
By their numbers in this assay, from the lowest: compounds 1 and 2 (each within the scatter of the next); then compound 4; then compound 3.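

Taking away the hydrogen-bond donor on this aromatic carbon is not enough on its own: compound 4 has none, yet the change brings only a 2.4-fold lower number from compound 3 to compound 4 (0.38 log units; beyond the scatter) and no return to the earlier numbers. Compound 4 also falls short of the two other rings without a donor, with a 5.5-fold higher number from compound 2 to compound 4 (0.74 log units; beyond the scatter) and a 7.3-fold higher number from compound 1 to compound 4 (0.86 log units; beyond the scatter) showing that the arrangement of the ring counts as well as the donor. Nothing measured here gives the reason for this. Left open is whether an ethyl group in place of the methyl on the ring nitrogen of compound 4, or fluorine in place of its chlorine, would move the number.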